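The source may hold more compounds than are shown below. What is called first, only, known or untested is meant among the compounds shown, and "the series" means these compounds.

Working notes on the ester series.

Three compounds are in hand. Compound 1 `COc1ccc(C(=O)Oc2cc3c(cc2C)[C@@H](C(C)C)CC=C3C)cc1` carries a 4-methoxyphenyl on the carbonyl carbon; compound 2 `CC1=CC[C@H](C(C)C)c2cc(C)c(OC(=O)c3cccc(C)c3)cc21` a 3-methylphenyl; compound 3 `CC1=CC[C@H](C(C)C)c2cc(C)c(OC(=O)c3ccc(Cl)cc3)cc21` a 4-chlorophenyl. In a functional assay on U-251 cells (Homo sapiens) for antiproliferative activity, read by sulforhodamine B assay, with a stated time of 48 h, tested at 50 uM (a higher number here means more inhibition at the concentration tested (going by the name of the read-out), a lower number less inhibition), compound 1 gives 37%, compound 2 gives 16.8%, and compound 3 gives 25.6%. Compound 3 thus stands second highest of the three numbers: the gap to compound 1 is beyond the scatter a number 11.4 percentage points lower from compound 1 to compound 3 (beyond the scatter), the gap to compound 2 is within it a number 8.8 percentage points higher from compound 2 to compound 3 (within the scatter). The step of a number 20.2 percentage points lower from compound 1 to compound 2 (beyond the scatter) is the largest seen so far.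

Compound 4 `CC1=CC[C@H](C(C)C)c2cc(C)c(OC(=O)c3ccc([N+](=O)[O-])cc3)cc21` is not yet measured. It differs from compound 3 in one place (nitro in place of chloro on an aromatic carbon). Within the data shown here, the only step that touches this same aromatic carbon is a number 11.4 percentage points lower from compound 1 to compound 3 (beyond the scatter), and the only step that changes the 4-substituent of that ring is the same one; no chloro-to-nitro exchange has been measured anywhere. The expectation for this assay is therefore a step of modest size at most, in no sure direction, quite possibly within the scatter; the step of a number 2.4 percentage points higher from compound 3 to compound 4 (within the scatter) is the estimate. For compound 4 the expected value is 28%, estimated to lie between 12% and 45%.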

Compound 4, a percentage reported as inhibition, at one concentration (the size of the read-out at that concentration, not a potency): 16.8%
Compound 4: the middle estimate sits 11.2 percentage points above what was measured; measured number inside the range.
By their numbers in this assay, from the lowest: compounds 2, 4 and 3 (each within the scatter of the next); then compound 1.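

The exchange of chloro for nitro at this aromatic carbon gives in this assay a number 8.8 percentage points lower from compound 3 to compound 4 (within the scatter) and so does not separate the two groups, although the entering nitro carries hydrogen-bond acceptors and the leaving chloro none. Changing the group on the carbonyl carbon gives no change at the digits printed from compound 2 to compound 4 (within the scatter) and also a number 20.2 percentage points lower from compound 1 to compound 4 (beyond the scatter); compound 1 is now beyond the scatter of all three other compounds, while compounds 2, 3 and 4 are not separated from their neighbours in the order. No measurement at hand bears on the reason for this result.

Among these compounds, whether the standing of compound 1 belongs to methoxy alone stays open, as it is the only compound with that group. An amine or a hydroxyl on the same aromatic carbon would show whether other groups reach the number of compound 1.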